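A few compounds are considered here, and "the series" means these few. Any claim that something is new, unique, unknown or untested is made for them only; others in the source may bear on it.

The series shares the core of compound 1, `CC(C)n1c(=O)[nH]c2ncc(Br)nc21`, whose entry in an ADME assay on microsomes from liver (Homo sapiens), read by LC-MS, with a stated time of 90 min (a higher number here means that the liver removes a larger share of the compound in one pass, a lower number that the liver removes a smaller share), stands as "not determined" (no result reported). Compound 2, `CCC(CC)n1c(=O)[nH]c2ncc(C)nc21`, carries methyl on the aromatic carbon; in this assay compound 2 gives < 0.2, which is a limit of the assay rather than a number. Compound 3, `CCC(CC)n1c(=O)[nH]c2ncc(OC)nc21`, carries methoxy in its place; in this assay compound 3 gives < 0.2, again a limit and not a number. Between them stands a step that the two limits leave unreadable from compound 2 to compound 3. Compound 3 thus sits at the limit of < 0.2 in this assay, at which 2 of the 3 values shown sit, and no single number exists anywhere on the series.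

Compound 4, `CCC(CC)n1c(=O)[nH]c2ncc(C#N)nc21`, is the next member: cyano in place of methoxy on an aromatic carbon. Within the data shown here, only the step from compound 2 to compound 3 bears on this change, and both of its ends rest at the limit, so no size of step can be drawn from it; the one reading available is that both measured members stay at the limit. Compound 4 is therefore expected to stay low in this assay, the step that the limit leaves unreadable from compound 3 to compound 4 being estimated as nothing beyond the scatter. The estimate for compound 4 is 0.15, in the range 0.05 to 0.35, with a real chance that the assay again reports only the limit.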

Compound 4, hepatic extraction ratio: < 0.2
Compound 4 gave a limit, no number; the forecaster's own chance of this, stated with the estimate: 60%; the middle value does not contradict the limit.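

In this assay compound 4 gives < 0.2, a limit and not a number. Among these compounds, no new step can therefore be read among compound 2, compound 3 and compound 4. The compounds shown leave open how methyl, methoxy and cyano on the aromatic carbon compare in hepatic extraction ratio, and whether any of these members has a value that can be put as a single number.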